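A few compounds are considered here, and "the series" means these few. Any claim that something is new, unique, unknown or untested is made for them only; others in the source may bear on it.

Of the compounds shown here, three sharing one core have been measured in a functional assay on A549 cells (Homo sapiens) for cytotoxicity, read by MTT assay, with a stated time of 72 h; on this read-out higher numbers stand for weaker inhibition and lower numbers for stronger inhibition. Compound 1 `CN(C)CCn1cnnc1-c1cc(Oc2ccc(NC(=O)N/N=C/c3ccccc3)cc2F)ccn1` gives 1860 nM. Compound 3 `CN(C)CCn1cnnc1-c1cc(Oc2ccc(NC(=O)N/N=C/c3cccc(Br)c3)cc2F)ccn1`, which carries bromo in place of hydrogen on an aromatic carbon, gives 970 nM, and the step of a 1.9-fold lower number from compound 1 to compound 3 (0.28 log units; within the scatter) stays within the scatter. Compound 2 `CN(C)CCn1cnnc1-c1cc(Oc2ccc(NC(=O)N/N=C/c3ccc(O)c(O)c3)cc2F)ccn1` returns only a limit, > 100000 nM, and not a number. One of the three values thus sits at the limit of > 100000 nM in this assay, at which 1 of the 3 values shown sits. Compound 3 therefore holds the lower of the two numbers, with compound 1 within the scatter of it, while the step of an at least 100-fold lower number from compound 2 to compound 3 (2.01 log units; beyond the scatter) lies far beyond the scatter.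

Compound 4 `COc1ccc(/C=N/NC(=O)Nc2ccc(Oc3ccnc(-c4nncn4CCN(C)C)c3)c(F)c2)cc1O` is not yet measured. It differs from compound 3 by 3-hydroxy-4-methoxyphenyl in place of 3-bromophenyl on a carbon with a double bond to nitrogen. Among the measured compounds shown here, two measured steps bear on this change: an at least 53-fold higher number from compound 1 to compound 2 (1.73 log units; beyond the scatter), where two hydroxyls enter the same ring, and an at least 100-fold lower number from compound 2 to compound 3 (2.01 log units; beyond the scatter), where they leave and bromo enters. Compound 4 keeps one hydroxyl and brings a methoxy, so a rise in this assay is expected, though smaller than for the dihydroxy case is plausible. The expected step is a 21-fold higher number from compound 3 to compound 4 (1.31 log units; beyond the scatter). For compound 4 the estimate is 20000 nM, within 3000 nM to 100000 nM.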

Compound 4, half-maximal inhibitory concentration: > 100000 nM
Compound 4 was reported as a limit (the forecaster's own chance of this, stated with the estimate: 30%); at least 5.0-fold (0.69 log units) between middle value and limit.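

On the ring attached to the carbon with a double bond to nitrogen, the loss seen with 3,4-dihydroxyphenyl is not confined to that one group: 3-hydroxy-4-methoxyphenyl shows it too, with an at least 100-fold higher number from compound 3 to compound 4 (2.01 log units; beyond the scatter) and an at least 53-fold higher number from compound 1 to compound 4 (1.73 log units; beyond the scatter). In this assay, methyl in place of hydrogen on an oxygen on an aromatic ring brings back no number, and compound 2 and compound 4 end at the same limit: the limit of > 100000 nM in this assay, at which 2 of the 4 values shown sit. The step between these two compounds cannot be read, as both values are limits.

The compounds shown leave open whether the loss needs a hydroxyl at all, or whether a phenyl carrying only methoxy would stay close to compound 3. They also do not tell how an amine or a carboxylic acid on this ring would read out.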